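Sulfonyl aryl change at the limit of the assay

The source may report more compounds than this note shows. Statements on the series, on what has been measured and on what is new or still open speak of the compounds shown alone.

Measured in an ADME assay on HEK293 cells (Homo sapiens) for antiproliferative activity, read by MTT assay, with a stated time of 48 h; on this read-out higher numbers stand for weaker inhibition and lower numbers for stronger inhibition:
- compound 1 `Cc1ccc(S(=O)(=O)n2cc(/C=C/C(=O)c3ccncc3)c3ccccc32)cc1`: > 150000 nM
- compound 2 `O=C(/C=C/c1cn(S(=O)(=O)c2cccc3ccccc23)c2ccccc12)c1ccncc1`: > 150000 nM

Compound 2 stands at > 150000 nM in this assay, and this is a limit and not a number. The value for compound 1 is likewise a limit. Going by the values given here, the series so far therefore rests on (the limit of > 150000 nM in this assay, at which 2 of the 2 values shown sit).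

Compound 3 `O=C(/C=C/c1cn(S(=O)(=O)c2ccc(Cl)cc2Cl)c2ccccc12)c1ccncc1` carries 2,4-dichlorophenyl in place of naphthalen-1-yl on a sulfonyl sulfur.

Among the compounds with values here, the only measured step at this place is a step that the two limits leave unreadable from compound 1 to compound 2, which offers no size and no direction to carry over. No step beyond the scatter is therefore expected, and another limit is the likeliest report. The expected step is a number no higher from compound 2 to compound 3 (the limit leaves the size open). For compound 3 the estimated value is 150000 nM, with an expected range from 60000 nM to 300000 nM.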

Compound 3, half-maximal inhibitory concentration: > 150000 nM
Compound 3: no number, only a limit (the forecaster's own chance of this, stated with the estimate: 75%); the middle value lies on the limit itself.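

No new step can be read: compound 1, compound 2 and compound 3 all stand as limits, not numbers, in this assay. The compounds shown leave open whether 4-methylphenyl, naphthalen-1-yl and 2,4-dichlorophenyl on the sulfonyl sulfur differ at all on this read-out.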